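The source may report more compounds than this note shows. Statements on the series, on what has been measured and on what is new or still open speak of the compounds shown alone.

Measured so far in a functional assay on the whole organism (strain Wistar) for inhibition, with Rattus norvegicus as the target, read by paw edema, with stated times of 30 min and 3 h, at a dose of 20 mg/kg by the oral route; on this read-out higher numbers stand for more inhibition at the one dose given (going by the name of the read-out) and lower numbers for less inhibition:
Compound 1 `Cc1cc(O)c(C2=NN(c3ccc(S(N)(=O)=O)cc3)C(/C=C/c3ccccc3)C2)cc1Cl` gives 78.9%.
Compound 2 `COc1cc(C)c(Cl)cc1C1=NN(c2ccc(S(N)(=O)=O)cc2)C(c2ccccc2)C1` gives 55.3%.
Compound 3 `COc1cc(C)c(Cl)cc1C1=NN(c2ccc(S(N)(=O)=O)cc2)C(c2cccc(O)c2)C1` gives 39.5%.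
Compound 4 `COc1cc(C)c(Cl)cc1C1=NN(c2ccc(S(N)(=O)=O)cc2)C(/C=C/c2ccccc2)C1` is not yet measured.

Compound 3 stands lowest of the three numbers. For the measured compounds named here, the only single-point step measured is a number 15.8 percentage points lower from compound 2 to compound 3 (beyond the scatter), for hydroxy in place of hydrogen on an aromatic carbon. Compound 1 lies furthest above compound 3, but differs from it in more than one place, so only the two values can be set side by side.

The change to compound 4 is 2-phenylethenyl in place of 3-hydroxyphenyl on a saturated ring carbon. Going by the values given here, no measured step covers this exchange directly. Compound 1 carries the same 2-phenylethenyl group and gives the highest number of the set, yet its other differences leave that as a hint only. A step upward beyond the scatter is expected, a number 22.5 percentage points higher from compound 3 to compound 4 (beyond the scatter), placing compound 4 near compound 2 or above it. Compound 4 is estimated at 62%, with a range of 45% to 78%.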

Compound 4, a percentage reported as inhibition, in the whole organism at one dose (the size of the read-out at that dose, not a potency): 55.3%
Compound 4: the middle estimate sits 6.7 percentage points above what was measured; the range from low to high includes it.
By their numbers in this assay, from the lowest: compound 3; then compounds 2 and 4 (each within the scatter of the next); then compound 1.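

In this assay the saturated ring carbon takes 2-phenylethenyl in place of phenyl with no change at the digits printed from compound 2 to compound 4 (within the scatter) as the whole effect, so the added double bond outside aromatic rings changes nothing measurable here. Against 3-hydroxyphenyl the same group gives a number 15.8 percentage points higher from compound 3 to compound 4 (beyond the scatter) and this matches the drop seen on adding hydroxy to phenyl. With 2-phenylethenyl held constant, methyl in place of hydrogen on the oxygen gives a number 23.6 percentage points lower from compound 1 to compound 4 (beyond the scatter) and so ties the high number of compound 1 to that oxygen rather than to 2-phenylethenyl alone. Open, as far as these compounds go, is whether an amine, a carboxylic acid or a longer chain on the saturated ring carbon would keep this level. No measurement at hand explains any of these steps.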